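The source may hold more compounds than are shown below. What is called first, only, known or untested is meant among the compounds shown, and "the series" means these compounds.

Measured compounds in an ADME assay on Vero cells (Chlorocebus sabaeus) for cytotoxicity, read by MTT assay, with a stated time of 72 h; a lower number here means that less compound is tolerated, a higher number that more compound is tolerated:
- compound 1 `NS(=O)(=O)c1ccc(N2N=C(c3ccc(F)cc3)CC2c2cn(-c3ccccc3)nc2-c2ccccc2)cc1`: > 807000 nM
- compound 2 `NS(=O)(=O)c1ccc(N2N=C(c3ccc(O)cc3)CC2c2cn(-c3ccccc3)nc2-c2ccccc2)cc1`: > 160000 nM
- compound 3 `NS(=O)(=O)c1ccc(N2N=C(c3ccc(F)cc3)CC2c2cn(-c3ccccc3)nc2-c2ccc(F)cc2)cc1`: > 753000 nM

Each of these three values is a limit of the assay and not a number. Compound 1 reaches only a limit (the limit of > 807000 nM in this assay, at which 1 of the 3 values shown sits). Compound 2 reaches only a limit (the limit of > 160000 nM in this assay, at which 1 of the 3 values shown sits). Compound 3 likewise reaches only a limit (the limit of > 753000 nM in this assay, at which 1 of the 3 values shown sits). Compound 3 therefore stands at a limit, and the two further values shown are limits as well, so no ordering among the three can be read.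

Compound 4 `NS(=O)(=O)c1ccc(N2N=C(c3ccc(O)cc3)CC2c2cn(-c3ccccc3)nc2-c2ccc(F)cc2)cc1` differs from compound 3 in one place: hydroxy in place of fluoro on an aromatic carbon. The measured steps that bear on this are a step that the two limits leave unreadable from compound 1 to compound 2, the same exchange at the same place, and a step that the two limits leave unreadable from compound 1 to compound 3, which joins compound 1 to compound 3; both are unreadable in size because the limit of > 807000 nM in this assay, at which 1 of the 3 values shown sits, and the limit of > 160000 nM in this assay, at which 1 of the 3 values shown sits, and the limit of > 753000 nM in this assay, at which 1 of the 3 values shown sits, bound every value. No step beyond the scatter is expected in this assay, and a limit is the likeliest outcome. Compound 4 is estimated at 700000 nM, between 150000 nM and 3000000 nM. The expected step of an at least 1.0-fold lower number from compound 3 to compound 4 (0.03 log units; that floor lies within the scatter) is accordingly no change beyond the scatter.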

Compound 4, half-maximal cytotoxic concentration: 32000 nM
For compound 4 the middle estimate is 22-fold (1.34 log units) above the measured one; measured number below the stated range.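

In this assay, among these compounds, the change from 4-fluorophenyl to 4-hydroxyphenyl now has a readable size, where the same exchange between the earlier compounds did not: an at least 23-fold lower number from compound 3 to compound 4 (1.37 log units; beyond the scatter). With hydroxy in place, fluoro in place of hydrogen on an aromatic carbon also gives a step beyond the scatter, an at least 5.0-fold lower number from compound 2 to compound 4 (0.69 log units; beyond the scatter), so less compound is tolerated with the two changes together than with hydroxy alone. Compound 4 carries both changes, and its value is the only one in the series that is not a limit.

As far as these compounds go, the steps among compound 1, compound 2 and compound 3 cannot be read, so the size of the hydroxy exchange without the added fluoro stays open. Also open, from the compounds shown here alone, is whether a methoxy group or an amine at the same place gives a step of similar size.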